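This account rests on a few compounds, and the source may have more. Where it says the series, first, only, none or still open, it means among the compounds named here.

Going by the values given here, compound 2 `Oc1cccc(-c2cc(-c3ccc(Cl)cc3)nc(-c3cccnc3)c2)c1` is the only compound in this small set with a reported number: in a functional assay on T47D cells (Homo sapiens) for cytotoxicity, read by CCK-8 assay and cell counting, with a stated time of 2 days (a higher number here means a weaker inhibitor, a lower number a stronger inhibitor), compound 2 gives 18100 nM. Among the compounds with values here, its companion compound 1 `Oc1cccc(-c2cc(-c3cccnc3)nc(-c3ccccc3Cl)c2)c1` is recorded in this assay only as "not determined" (no result reported), so compound 2 stands alone as a reference point, and no step between two measured compounds can be drawn from what is available.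

The question is how compound 3 `Oc1cccc(-c2cc(-c3ccc(Cl)cc3)nc(-c3ccccn3)c2)c1` will behave. Compound 3 is built from the same atoms as compound 2, joined differently: the change is pyridin-2-yl in place of pyridin-3-yl on an aromatic carbon. Within the data shown here, nothing among the measured compounds bears directly on this swap, so any expectation has to rest on the weak cytotoxicity of compound 2 in this assay and on the fact that the change keeps the shared core and the remaining groups unchanged.

On that basis the step from compound 2 to compound 3 is expected to be small, a 1.2-fold lower number from compound 2 to compound 3 (0.08 log units; within the scatter), with no direction that can be argued beyond the usual scatter. The value for compound 3 in this assay is therefore estimated at 15000 nM, within a range of 5000 nM to 45000 nM.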

Compound 3, half-maximal inhibitory concentration: 13900 nM
Beside the measured number, compound 3's estimate is 1.1-fold (0.03 log units) above it; the range from low to high includes it.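

In this assay, pyridin-2-yl in place of pyridin-3-yl gives a 1.3-fold lower number from compound 2 to compound 3 (0.11 log units; within the scatter), so this pair cannot be told apart in this test. Going by these compounds alone, it is the first comparison here with a number on both sides, and it shows that on this aromatic carbon, next to the ring nitrogen, meta to a 3-hydroxyphenyl group and meta to a 4-chlorophenyl group, the two pyridine attachments read alike, with the rest of the structure held fixed. No independent measurement is at hand that would account for this result.

The compounds shown leave open whether this carbon would tolerate other groups equally well, for example pyridin-4-yl, a plain phenyl ring, a morpholine or a carboxylic acid, since only two attachments of the same pyridine ring can be compared so far. They also leave open whether the same swap would read alike with an amine or a methoxy group in place of the hydroxyl on the 3-hydroxyphenyl group, or with a fluorine in place of the chlorine on the 4-chlorophenyl group.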